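The compounds below may be only part of what the source reports. "The series", "measured", "known", "first", "only" and "open" are said of these compounds alone.

Of the compounds shown here, three that share one core have so far been measured. Compound 1 `Cc1ccccc1-n1nc(C)c2c1NC(=O)[C@H](C)S[C@@H]2c1ccc(-c2ccoc2)cc1` carries a furan-3-yl group on its outer benzene ring and, in an assay on isolated protein for agonist activity at Bile acid receptor (Homo sapiens), read by AlphaScreen, with a stated time of 30 min (a higher number here means that more compound is needed for the effect, a lower number that less compound is needed), compound 1 gives 3500 nM. Compound 2 `Cc1nn(-c2ccccc2I)c2c1C(c1ccc(Oc3ccccc3)cc1)SC(C)C(=O)N2` replaces that group with a phenoxy group and gives 1300 nM. Compound 3 `COc1ccccc1-n1nc(C)c2c1NC(=O)[C@H](C)S[C@@H]2c1ccc(Oc2ccccc2)cc1` keeps the phenoxy group but changes the substituent on the other outer ring, and gives 3300 nM. Among these three numbers compound 1 stands highest, meaning the most compound is needed; its value sits within the usual scatter of that of compound 3, so the two cannot be ordered, while the gap to compound 2 lies beyond the scatter.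

The next compound, compound 4 `Cc1ccccc1-n1nc(C)c2c1NC(=O)[C@H](C)S[C@@H]2c1ccc(-c2cc3ccccc3o2)cc1`, differs from compound 1 in a single place: 1-benzofuran-2-yl in place of furan-3-yl on an aromatic carbon. The furan ring grows into a fused two-ring system, keeping its single oxygen.

Going by the values given here, no pair of measured compounds isolates this change, so any forecast rests on the compounds described. For compound 4 a modest step toward a lower number is expected, a 1.8-fold lower number from compound 1 to compound 4 (0.24 log units; within the scatter), though one that may well stay within the scatter. The estimate for compound 4 is 2000 nM, with a range from 600 nM to 7000 nM.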

Compound 4, half-maximal effective concentration: 1500 nM
Estimate against measurement, compound 4: 1.3-fold (0.12 log units) above, and the stated range covers the measured number.
By their numbers in this assay, from the lowest: compounds 2 and 4 (each within the scatter of the next); then compounds 3 and 1 (each within the scatter of the next).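

Putting 1-benzofuran-2-yl in place of furan-3-yl, on the aromatic carbon para to a large group, gives in this assay a 2.3-fold lower number from compound 1 to compound 4 (0.37 log units; beyond the scatter), a modest step but one that lies beyond the usual scatter. Going by these compounds alone, this is the first pair that differs in only one place, and it shows that the number responds to the group at this position: going from 5 heavy atoms to 9, with an added six-membered aromatic ring and the same count of hydrogen-bond acceptors, does not raise the number but lowers it. Nothing measured here explains why the larger group gives this result.

The change alters two things at once, adding a fused benzene ring and moving the point of attachment on the furan ring, so a furan-2-yl group at this place would be needed to tell these two apart. Also open, as far as these compounds go, is how the number would respond to a group of a different kind here, such as an amine or a carboxylic acid.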